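This account rests on a few compounds, and the source may have more. Where it says the series, first, only, none or still open, it means among the compounds named here.

Three compounds share one core and differ only in the group on the carbonyl carbon attached to the ring nitrogen. In a functional assay on U2OS cells for antagonist activity at proto-oncogene Wnt-3 (Homo sapiens), read by a luciferase reporter, with a stated time of 18 h (on this read-out higher numbers stand for an effect only at larger amounts of compound and lower numbers for an effect already at smaller amounts), compound 1 `CC(C)C(=O)N1CCC[C@H]1C(=O)N1CCC(NS(=O)(=O)c2cc(S(=O)(=O)c3ccccc3)ccc2C(F)(F)F)CC1` gives 90 nM. Compound 2 `CC(C)(C)C(=O)N1CCC[C@H]1C(=O)N1CCC(NS(=O)(=O)c2cc(S(=O)(=O)c3ccccc3)ccc2C(F)(F)F)CC1` gives 270 nM in this assay, and the step reads a 3.0-fold higher number from compound 1 to compound 2 (0.48 log units; beyond the scatter). Compound 3 `CN(C)c1ccc(C(=O)N2CCC[C@H]2C(=O)N2CCC(NS(=O)(=O)c3cc(S(=O)(=O)c4ccccc4)ccc3C(F)(F)F)CC2)cc1` gives 830 nM in this assay, the highest of the three numbers; the steps leading to it are a 9.2-fold higher number from compound 1 to compound 3 (0.96 log units; beyond the scatter) and a 3.1-fold higher number from compound 2 to compound 3 (0.49 log units; beyond the scatter). Compound 4 `O=C([C@@H]1CCCN1C(=O)c1ccncc1)N1CCC(NS(=O)(=O)c2cc(S(=O)(=O)c3ccccc3)ccc2C(F)(F)F)CC1` has not yet been measured in this assay. It differs from compound 3 by pyridin-4-yl in place of 4-(dimethylamino)phenyl on a carbonyl carbon. For the measured compounds named here, none of the measured steps exchanges one aromatic ring for another: both steps that end at compound 3 replace a saturated group with the 4-(dimethylamino)phenyl group and are of modest size. Compound 4 keeps a six-membered aromatic ring on the carbonyl carbon, so the expectation for it rests on compound 3 alone and is held loosely. Compound 4 is expected to give 700 nM in this assay, with a range from 250 nM to 2000 nM. The expected step is a 1.2-fold lower number from compound 3 to compound 4 (0.07 log units; within the scatter), not beyond the scatter.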

Compound 4, half-maximal effective concentration: 350 nM
Estimate against measurement, compound 4: 2.0-fold (0.30 log units) above; measured number inside the range.
By their numbers in this assay, from the lowest: compound 1; then compounds 2 and 4 (each within the scatter of the next); then compound 3.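

In this assay, exchanging one aromatic ring for another on this carbonyl carbon shifts the number beyond the scatter: pyridin-4-yl in place of 4-(dimethylamino)phenyl gives a 2.4-fold lower number from compound 3 to compound 4 (0.38 log units; beyond the scatter), so the identity of the ring counts here, not only its presence. The pyridin-4-yl group also stands level with tert-butyl, with a 1.3-fold higher number from compound 2 to compound 4 (0.11 log units; within the scatter), so an aromatic ring on this carbon does not by itself give the highest number. Isopropyl still keeps the lowest number, with a 3.9-fold higher number from compound 1 to compound 4 (0.59 log units; beyond the scatter).

Nothing available explains these differences. The step from compound 3 to compound 4 alters both the ring atoms and the dimethylamino group at once, so plain phenyl, pyridin-3-yl or pyridin-2-yl on this carbonyl carbon would be needed to separate the two changes.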